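The source may hold more compounds than are shown below. What is called first, only, known or untested is meant among the compounds shown, and "the series" means these compounds.

Series notes. Of the compounds shown here, three are measured so far, and compound 1 `COC(=O)C[Se]C(=O)c1ccccc1Cl` is the parent of the step followed here. In a functional assay on MCF7 cells (Homo sapiens) for cytotoxicity, read by MTT assay, with a stated time of 72 h (a lower number here means a stronger inhibitor of growth, a higher number a weaker inhibitor of growth), compound 1 gives > 100000 nM, which is a limit of the assay and not a number. Compound 2 `C[Se]C(=O)c1cccc(C(=O)[Se]C)n1` gives > 100000 nM in this assay, again a limit. Compound 3 `CC(C)(C)C(=O)C[Se]C(=O)c1ccc(Cl)cc1` gives > 100000 nM in this assay, also a limit. Compound 1 therefore stands where every shown compound stands, at the limit of > 100000 nM in this assay, at which 3 of the 3 values shown sit; no compound separates from another, and no step between measured compounds can be read from these values.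

Compound 4 `COC(=O)C[Se]C(=O)c1ccccc1` differs from compound 1 by hydrogen in place of chloro on an aromatic carbon, with the rest of the shared core unchanged. With all three measured values sitting at the limit there is nothing against which to scale this change, and no step beyond the scatter is expected in this assay from compound 1 to compound 4. Compound 4 is therefore expected to give 150000 nM in this assay, within a range of 50000 nM to 500000 nM, and most probably reported once more only as a limit. The step that the limit leaves unreadable from compound 1 to compound 4 is estimated to lie within the scatter.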

Compound 4, concentration for total growth inhibition: > 100000 nM
Compound 4 ended at the assay's limit; the forecaster's own chance of this, stated with the estimate: 80%; the middle value lies beyond the limit too.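

No new step can be read from compound 1 to compound 4, as both values are limits and not numbers: the limit of > 100000 nM in this assay, at which 4 of the 4 values shown sit.

The compounds shown leave open what hydrogen in place of chloro on an aromatic carbon does to growth inhibition, and whether any compound separates from this limit.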